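The source may hold more compounds than are shown below. What is called first, only, known or untested is meant among the compounds shown, and "the series" means these compounds.

Measured compounds:
compound 1, `Cc1nc2c(OCc3ccccc3)cccn2c1CO`, 99%
compound 2, `Cc1nc2c(OCc3ccccc3)cccn2c1Br`, 26%

The two compounds were tested in a functional assay on the whole organism with Rattus norvegicus as the target, with a stated time of 4 h, at a dose of 40 mg/kg by the intraperitoneal route; on this read-out higher numbers stand for more inhibition at the one dose given (going by the name of the read-out) and lower numbers for less inhibition. Compound 1 `Cc1nc2c(OCc3ccccc3)cccn2c1CO` has the higher number of the two: in this assay compound 1 gives 99%, the highest of the two numbers, while compound 2 `Cc1nc2c(OCc3ccccc3)cccn2c1Br` gives 26%. Among the measured compounds shown here, the one measured step, a number 73 percentage points lower from compound 1 to compound 2 (beyond the scatter), is well beyond the scatter and shows that removing the hydroxymethyl group in favour of bromo costs most of the inhibition.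

Compound 3 `CCCCC(=O)OCc1c(C)nc2c(OCc3ccccc3)cccn12` has not yet been measured. It differs from compound 1 in one place: butylcarbonyl in place of hydrogen on an oxygen on a saturated carbon. The hydroxymethyl of compound 1 is thus kept in its carbon skeleton, but its oxygen no longer carries a hydrogen. The step from compound 1 to compound 2 is the only one that bears on this change, and it bears on it only loosely, since there the whole hydroxymethyl group was exchanged rather than capped. Because a number 73 percentage points lower from compound 1 to compound 2 (beyond the scatter) was so large, the hydroxymethyl appears to matter, and capping it is expected to cost something, though less than its full loss. The expected step is a number 27 percentage points lower from compound 1 to compound 3 (beyond the scatter). Compound 3 is estimated at 72%, within a range from 35% to 99%.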

Compound 3, a percentage reported as inhibition, in the whole organism at one dose (the size of the read-out at that dose, not a potency): 45%
Compound 3: the middle estimate sits 27 percentage points above what was measured; the range from low to high includes it.
By their numbers in this assay, from the lowest: compound 2; then compound 3; then compound 1.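

In this assay, capping the oxygen of the hydroxymethyl with butylcarbonyl leaves the carbon skeleton in place yet still gives a number 54 percentage points lower from compound 1 to compound 3 (beyond the scatter), so at this position the free hydroxy itself counts, and not only the carbon that carries it. The capped group is nevertheless not equal to bromo on the aromatic carbon: the exchange of bromo for ((butylcarbonyl)oxy)methyl gives a number 19 percentage points higher from compound 2 to compound 3 (beyond the scatter), which shows that part of the inhibition survives the cap. The three compounds thus form a graded series at one position, and the fall on capping is the larger part of the whole distance from the hydroxymethyl to bromo. Nothing measured here speaks to why the cap lowers the number.

The compounds shown leave open whether this loss belongs to the butylcarbonyl chain in particular or to any group on that oxygen, which a small acetyl group, a longer acyl chain or a methyl ether would help to settle. As far as these compounds go, it also remains open whether an amine in place of the hydroxy could keep the inhibition, and whether the order holds at other doses and times.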